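Adding a Methoxy Group to Compound 1

This account rests on a few compounds, and the source may have more. Where it says the series, first, only, none or still open, it means among the compounds named here.

Compound 1, `COc1ccc(-c2[nH]c3ccccc3c2/C=C(\C#N)S(=O)(=O)c2ccccc2)cc1`: 398 nM
Compound 2, `COc1ccc2[nH]c(-c3ccccc3)c(C=C(C#N)C#N)c2c1`: 2200 nM
Compound 3, `CCOC(=O)C(=Cc1c(-c2ccccc2)[nH]c2ccccc12)C(=O)OCC`: 4500 nM

In a functional assay on MCF7 cells (Homo sapiens) for inhibition, read by sulforhodamine B assay, with a stated time of 48 h (a lower number here means a stronger inhibitor of growth, a higher number a weaker inhibitor of growth), compound 1 gives the lowest of the three numbers. Compound 2 gives a higher number, beyond the scatter, and compound 3 gives a higher number still, also beyond the scatter. For the measured compounds named here, no two of these three compounds differ in a single place, so no isolated step is available from them.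

Compound 4, `COc1ccc(-c2[nH]c3ccc(OC)cc3c2/C=C(\C#N)S(=O)(=O)c2ccccc2)cc1`, has not yet been measured in this assay. It differs from compound 1 in one place: methoxy in place of hydrogen on an aromatic carbon. Compound 2 also carries a methoxy on its core, but it differs from compound 1 in other parts as well, so its value cannot show what the methoxy alone does.

With nothing to anchor the change, the step from compound 1 to compound 4 is expected to be small and could go in either direction; the expected step is a 1.1-fold higher number from compound 1 to compound 4 (0.05 log units; within the scatter). For compound 4 the estimate in this assay is 450 nM, expected to fall between 150 nM and 1400 nM.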

Compound 4, concentration for 50% growth inhibition: 851 nM
For compound 4 the middle estimate is 1.9-fold (0.28 log units) below the measured one; the range from low to high includes it.
By their numbers in this assay, from the lowest: compound 1; then compound 4; then compound 2; then compound 3.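

In this assay, for the compounds shown here, the step for methoxy in place of hydrogen is a 2.1-fold higher number from compound 1 to compound 4 (0.33 log units; beyond the scatter), the first single change that can be read. It shows that this aromatic carbon of the fused system, meta to a fused ring and para to a fused ring, is sensitive to substitution: the change is modest but lies beyond the usual scatter, and it moves towards weaker growth inhibition. Nothing available explains the direction or size of this step.

The compounds shown leave open whether a hydroxyl, a fluorine or a longer chain such as ethoxy on this same carbon would give a step of similar size. They also leave open whether methoxy on another aromatic carbon of the shared core would behave in the same way.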